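The source may hold more compounds than are shown below. What is called first, only, known or untested is meant among the compounds shown, and "the series" means these compounds.

Compound 1, `CC[C@@H](CCn1cncn1)c1ccc(C)cc1`, in an ADME assay on HEp-2 cells (Homo sapiens) for cytotoxicity, read by MTT assay, with a stated time of 3 days (a higher number here means that more compound is tolerated, a lower number that less compound is tolerated), compound 1 gives 69.9 ug/mL. Compound 2, `COc1ccc([C@H](CCn2cncn2)Cc2ccccc2)cc1`, in this assay compound 2 gives 60.3 ug/mL. Compound 3, `Cc1ccc([C@@H](CCn2cncn2)Cc2ccccc2)cc1`, in this assay compound 3 gives 83.3 ug/mL.

Compound 3 stands at the top of these three numbers as written, yet compound 1 and compound 2 both fall within the usual scatter of it, so the three cannot be told apart with confidence. Compound 4, `Cc1ccc([C@H](CCn2cncn2)Cc2ccccc2)cc1`, is the mirror-image partner of compound 3: the two compounds have the same atoms and bonds and differ only in configuration as drawn: 1 of 1 stereo elements differ; a stereocentre at a saturated chain carbon is drawn R in compound 3 and S in compound 4. Going by the values given here, no pair among the measured compounds differs in this way alone, so the data give no measured step for such a change. Cytotoxicity toward a cell line is usually not very sensitive to which mirror image is tested, and the three measured values already sit close together, so the expected step from compound 3 to compound 4 in this assay is a 1.0-fold lower number from compound 3 to compound 4 (0.02 log units; within the scatter), that is, none beyond the scatter. On that basis compound 4 is estimated at 80 ug/mL, with a likely range from 45 ug/mL to 140 ug/mL.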

Compound 4, half-maximal cytotoxic concentration: 152 ug/mL
Beside the measured number, compound 4's estimate is 1.9-fold (0.28 log units) below it; the whole stated range lies below it.
By their numbers in this assay, from the lowest: compounds 2, 1, 3 and 4 (each within the scatter of the next, the first and the last beyond it).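

In this assay, a change of configuration at this saturated chain carbon now has a measured step, a 1.8-fold higher number from compound 3 to compound 4 (0.26 log units; within the scatter), and it does not establish a preference for either mirror image. Going by these compounds alone, this comparison is a clean one: the fact that compounds 3 and 4 differ only in the configuration as drawn Compound 4 also supplies the first steps in this set that pass the scatter, both modest: methyl in place of methoxy on an aromatic carbon gives a 2.5-fold higher number from compound 2 to compound 4 (0.40 log units; beyond the scatter), and phenyl in place of methyl on a saturated chain carbon, two bonds along the chain from an aromatic carbon, gives a 2.2-fold higher number from compound 1 to compound 4 (0.34 log units; beyond the scatter).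

The compounds shown leave open whether the mirror-image step would look the same with methoxy on the aromatic carbon. They also leave open how a chlorine or an amine there, or a longer chain in place of the phenyl, would read in this assay.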